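Dropping One Trifluoromethyl from a Diaryl Urea

The source may report more compounds than this note shows. Statements on the series, on what has been measured and on what is new or still open speak of the compounds shown alone.

Measured so far in a functional assay on KM12 cells (Homo sapiens) for inhibition, read by sulforhodamine B assay, with a stated time of 48 h; on this read-out higher numbers stand for weaker inhibition of growth and lower numbers for stronger inhibition of growth:
- Compound 1, `COc1cc(-c2nn(-c3cccc(NC(=O)Nc4cc(C(F)(F)F)cc(C(F)(F)F)c4)c3)cc2-c2ccncc2)ccc1Cl`, gives 1340 nM in this assay.
- Compound 2, `O=C(Nc1cccc(-n2cc(-c3ccncc3)c(-c3ccc(Cl)c(O)c3)n2)c1)Nc1ccc(Cl)c(Cl)c1`, gives 4470 nM in this assay.

Of these two compounds, compound 1 has the lower number, and compound 2 lies a clear distance above it, beyond the usual scatter of repeated measurements. Compound 3, `COc1cc(-c2nn(-c3cccc(NC(=O)Nc4cccc(C(F)(F)F)c4)c3)cc2-c2ccncc2)ccc1Cl`, keeps the core of compound 1 and changes only one end of the urea: hydrogen in place of trifluoromethyl on an aromatic carbon. Going by the values given here, no measured pair shows this exact change, so its effect is not known from the data at hand. A small loss of growth inhibition in this assay seems the most likely outcome, though a result within the scatter would not be surprising. Compound 3 is therefore expected to show a step of a 1.6-fold higher number from compound 1 to compound 3 (0.22 log units; within the scatter) in this assay. The estimate for compound 3 in this assay is 2200 nM, with a range from 900 nM to 5500 nM.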

Compound 3, concentration for total growth inhibition: 1980 nM
Compound 3: middle estimate off by 1.1-fold (0.05 log units), on the high side; low and high end bracket the measured number.
By their numbers in this assay, from the lowest: compounds 1 and 3 (each within the scatter of the next); then compound 2.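

Going by these compounds alone, this is the first pair that differs in one place only, so it is the first direct look at what one trifluoromethyl on the urea's outer aromatic ring contributes. In this assay, hydrogen in place of the trifluoromethyl gives a 1.5-fold higher number from compound 1 to compound 3 (0.17 log units; within the scatter), so the two compounds cannot be told apart on this read-out, and on this core a single trifluoromethyl on that ring, at the place meta to the one that left, reads the same as two. No measurement at hand offers a reason for this result. What the compounds shown leave open is whether an amine or a carboxylic acid on the same carbon would also read the same. Also open, on these data alone, is what would happen if the remaining trifluoromethyl gave way to hydrogen as well, leaving that ring with no substituent other than the urea.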